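A Phenyl-Bearing Acid Replaces the Hydroxycyclohexyl Group

The source may hold more compounds than are shown below. What is called first, only, known or untested is meant among the compounds shown, and "the series" means these compounds.

Three compounds share a core and were tested in an assay on HEK293 cells for displacement of a labelled ligand from melanin-concentrating hormone receptor 1 (Homo sapiens); a higher number here means a weaker inhibitor, a lower number a stronger inhibitor. Compound 1 `O=C(NC1CCN(Cc2ccn(-c3ccc(C(F)(F)F)cc3)c2)CC1)N1CCn2cccc2C1c1ccccc1` gives 10 nM, compound 3 `CN1CCN(C(=O)NC2CCN(Cc3ccn(-c4ccc(C(F)(F)F)cc4)c3)CC2)C(c2ccccc2)C1` gives 28 nM, and compound 2 `O=C(NC[C@H]1CCCC[C@H]1O)NC1CCN(Cc2ccn(-c3ccc(C(F)(F)F)cc3)c2)CC1` gives 63 nM, the highest of the three numbers and beyond the scatter from both others. Compound 4 `O=C(O)CC(NC(=O)NC1CCN(Cc2ccn(-c3ccc(C(F)(F)F)cc3)c2)CC1)c1ccccc1` is not yet measured. It differs from compound 2 by 2-carboxy-1-phenylethyl in place of (2-hydroxycyclohexyl)methyl on an amide-type nitrogen, so a phenyl ring sits on the urea side as it does in compound 1 and compound 3. Within the data shown here, no measured pair isolates this change. The step of a 1.4-fold lower number from compound 2 to compound 4 (0.15 log units; within the scatter) is expected to be small, most likely a modest move towards a lower number or none beyond the scatter. Compound 4 is estimated at 45 nM, within 12 nM to 180 nM.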

Compound 4, half-maximal inhibitory concentration: 412 nM
For compound 4 the middle estimate is 9.2-fold (0.96 log units) below the measured one, and the stated range ends below it.
By their numbers in this assay, from the lowest: compound 1; then compound 3; then compound 2; then compound 4.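

In this assay, the group on this amide-type nitrogen clearly matters: 2-carboxy-1-phenylethyl in place of (2-hydroxycyclohexyl)methyl gives a 6.5-fold higher number from compound 2 to compound 4 (0.82 log units; beyond the scatter), a weaker inhibitor. The entering group brings a phenyl ring and a carboxylic acid together, and this one step cannot separate their contributions. Nothing shown here explains the direction or size of the step.

From the compounds shown here alone, it remains open whether a plain 1-phenylethyl group, with no carboxylic acid, or the methyl ester of that acid would bring the number back towards that of compound 2.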